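The compounds below may be only part of what the source reports. "The series", "measured", "known", "first", "only" and "open" are said of these compounds alone.

Measured compounds:
- compound 1 `CC(C)(C)c1ccc(CNCCCNS(=O)(=O)c2cc(C(F)(F)F)cc(C(F)(F)F)c2)cc1` gives 2900 nM in a functional assay on A2780 cells (Homo sapiens) for inhibition, read by MTT assay, with a stated time of 72 h; on this read-out higher numbers stand for weaker inhibition of growth and lower numbers for stronger inhibition of growth
- compound 2 `O=S(=O)(NCCCCNCc1ccc(Br)cc1)c1cc(C(F)(F)F)cc(C(F)(F)F)c1` gives 2100 nM in this assay

Compound 1 carries the highest of the two numbers in this assay, yet its nearest neighbour, compound 2, sits within the usual scatter of it, so nothing separates the two in growth inhibition on this read-out. Among the measured compounds shown here, no single-change step between these two measured compounds is available, since compound 2 also differs from compound 1 in the length of the chain between the two nitrogens and in the group on the benzyl ring.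

Compound 3 `COc1ccc(CNCCCNS(=O)(=O)c2cc(C(F)(F)F)cc(C(F)(F)F)c2)cc1OC` has not yet been measured. Its structure is compound 1 with 3,4-dimethoxyphenyl in place of 4-(tert-butyl)phenyl on a saturated chain carbon bound to an amine nitrogen. With no measured step of this kind to lean on, the account can only reason from the two values shown, which themselves lie within the scatter of each other. The step from compound 1 to compound 3 is therefore expected to be small, a 1.2-fold higher number from compound 1 to compound 3 (0.08 log units; within the scatter), with no firm direction beyond the scatter. Compound 3 is expected to give about 3500 nM in this assay, within a range from 1200 nM to 10000 nM.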

Compound 3, concentration for 50% growth inhibition: 3800 nM
Estimate against measurement, compound 3: 1.1-fold (0.04 log units) below; the range from low to high includes it.
By their numbers in this assay, from the lowest: compounds 2, 1 and 3 (each within the scatter of the next).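

In this assay, among the compounds shown here, the change from 4-(tert-butyl)phenyl to 3,4-dimethoxyphenyl on a saturated chain carbon bound to an amine nitrogen gives the first single-change step at this position: a 1.3-fold higher number from compound 1 to compound 3 (0.12 log units; within the scatter). The group that leaves has 10 carbon and no hydrogen-bond acceptors, and the group that enters has 8 carbon, 2 oxygen and 2 hydrogen-bond acceptors, yet the read-out does not separate compound 1 from compound 3. At this place on the core of compound 1, then, swapping these two substituted phenyl groups of 10 heavy atoms each leaves growth inhibition unresolved, and nothing at hand bears on why this is so.

The compounds shown leave open whether a carboxylic acid or a morpholine on the same ring, or a pyridine in place of that ring, would give a step beyond the scatter. They also leave open whether 3,4-dimethoxyphenyl would read the same on the chain of compound 2.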